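The compounds below may be only part of what the source reports. "The series", "measured", "known", "first", "only" and "open" are said of these compounds alone.

Of the compounds shown here, two have so far been tested in a functional assay for agonist activity at Bombesin receptor subtype-3 (Homo sapiens); a lower number here means that less compound is needed, a higher number that more compound is needed for the effect. Compound 1 `c1ccc(-c2nnn[nH]2)c(-c2ccc(CCc3nc(CC4CCCC4)c[nH]3)cc2)c1` gives 56 nM. Compound 2 `CCC(C)(C)Cc1c[nH]c(CCc2ccc(-c3ccccc3OCC(=O)O)cc2)n1` gives 54 nM, the lowest of the two numbers, though only within the scatter of compound 1. Compound 3 `CCC(C)(C)Cc1c[nH]c(CCc2ccc(-c3ccccc3OCc3nc(C(F)(F)F)n[nH]3)cc2)n1` has not yet been measured; it differs from compound 2 in one place: 3-(trifluoromethyl)-1H-1,2,4-triazol-5-yl in place of carboxy on a saturated chain carbon bound to an oxygen on an aromatic ring. Going by the values given here, no pair of measured compounds shares a single difference, so no measured step guides the expectation. The step is expected to be small, no larger than the scatter, as a 1.0-fold higher number from compound 2 to compound 3 (0.01 log units; within the scatter). Compound 3 is therefore estimated at 55 nM, likely between 20 nM and 160 nM.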

Compound 3, half-maximal effective concentration: 129 nM
Beside the measured number, compound 3's estimate is 2.3-fold (0.37 log units) below it; measured number inside the range.
By their numbers in this assay, from the lowest: compounds 2 and 1 (each within the scatter of the next); then compound 3.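

Placing 3-(trifluoromethyl)-1H-1,2,4-triazol-5-yl instead of carboxy on this saturated chain carbon gives a 2.4-fold higher number from compound 2 to compound 3 (0.38 log units; beyond the scatter) in this assay. This position therefore tolerates a larger, ring-bearing group without a net charge, and agonist activity remains, though more compound is needed. Nothing available here explains the shift. Still open, on these data alone, is how much of the step belongs to the ring and how much to its trifluoromethyl. A methyl group on the same ring, or an amide in place of the ring, would help separate the two.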